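This account rests on a few compounds, and the source may have more. Where it says the series, first, only, none or still open, it means among the compounds named here.

Measured in a functional assay on ASPC1 cells (Homo sapiens) for inhibition, read by MTT assay, with a stated time of 72 h; on this read-out higher numbers stand for weaker inhibition of growth and lower numbers for stronger inhibition of growth:
- compound 1 `COc1ccc(CNCCCNS(=O)(=O)c2cc(C(F)(F)F)cc(C(F)(F)F)c2)cc1OC`: 6400 nM
- compound 2 `COc1cccc(CNCCCNS(=O)(=O)c2cc(C(F)(F)F)cc(C(F)(F)F)c2)c1`: 3800 nM
- compound 3 `O=S(=O)(NCCCNCc1cccc(Cl)c1)c1cc(C(F)(F)F)cc(C(F)(F)F)c1`: 5900 nM

Compound 1 has the highest of the three numbers, but its gaps to the others, a 1.1-fold lower number from compound 1 to compound 3 (0.04 log units; within the scatter) and a 1.7-fold lower number from compound 1 to compound 2 (0.23 log units; within the scatter), both lie within the scatter, so the three compounds cannot be separated on this read-out.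

Compound 4 `COc1ccccc1CNCCCNS(=O)(=O)c1cc(C(F)(F)F)cc(C(F)(F)F)c1` differs from compound 1 by 2-methoxyphenyl in place of 3,4-dimethoxyphenyl on a saturated chain carbon bound to an amine nitrogen.

Among the compounds with values here, the steps that bear on this change are a 1.7-fold lower number from compound 1 to compound 2 (0.23 log units; within the scatter), where a methoxy is removed, and a 1.1-fold lower number from compound 1 to compound 3 (0.04 log units; within the scatter), where the whole aryl group is exchanged; a 1.6-fold higher number from compound 2 to compound 3 (0.19 log units; within the scatter) adds a third comparison of the same kind. All three are within the scatter, so the step to compound 4 is expected to be no larger: a 1.3-fold lower number from compound 1 to compound 4 (0.11 log units; within the scatter).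

Compound 4 is therefore estimated at 5000 nM, with a range from 2500 nM to 10000 nM.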

Compound 4, concentration for 50% growth inhibition: 4600 nM
For compound 4 the middle estimate is 1.1-fold (0.04 log units) above the measured one; the measured number falls inside the stated range.
By their numbers in this assay, from the lowest: compounds 2, 4, 3 and 1 (each within the scatter of the next).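

In this assay the 2-methoxyphenyl group reads the same as the other aryl groups within the scatter, against 3,4-dimethoxyphenyl (a 1.4-fold lower number from compound 1 to compound 4 (0.14 log units; within the scatter)) and against 3-chlorophenyl (a 1.3-fold lower number from compound 3 to compound 4 (0.11 log units; within the scatter)). New here is a change in where the single methoxy stands, 2-methoxyphenyl in place of 3-methoxyphenyl, which also stays within the scatter (a 1.2-fold higher number from compound 2 to compound 4 (0.08 log units; within the scatter)), so the four aryl groups cannot be separated on this read-out. Nothing at hand accounts for this lack of separation.

Still open, as far as these compounds go, is whether a carboxylic acid or an amine on the aryl group, or a longer chain in the shared core, would give a step beyond the scatter.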